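The source may report more compounds than this note shows. Statements on the series, on what has been measured and on what is new or still open speak of the compounds shown alone.

In a functional assay on HeLa cells (Homo sapiens) for cytotoxicity, read by MTT assay, with a stated time of 48 h (a lower number here means a stronger inhibitor, a higher number a weaker inhibitor), compound 2 (`C=C(c1ccc(OC)cc1)c1cc(OC)c(OC)c(OC)c1-c1ccccc1`) gives 11000 nM. Among the compounds with values here, its only measured neighbour, compound 1 (`C=C(c1ccc(OC)cc1)c1cc(OC)c(OC)c(OC)c1-c1ccc(F)c(F)c1`), gives 5900 nM, so the two lie within the scatter of each other and compound 2 has no firm rank. The next change leads to compound 3 (`C=C(c1ccc(OC)cc1)c1cc(OC)c(OC)c(OC)c1-c1ccc(C(C)(C)C)cc1`), with tert-butyl in place of hydrogen on an aromatic carbon, para to a large group: tert-butyl in place of hydrogen on an aromatic carbon. Within the data shown here, only one measured step bears on this change, as it alters the same aromatic substituent: a 1.9-fold higher number from compound 1 to compound 2 (0.27 log units; within the scatter), within the scatter. Among the measured compounds shown here, that step gives only weak guidance, and no measured compound carries a tert-butyl group. No step beyond the scatter is therefore expected in this assay, in either direction. The expected result is a 1.1-fold higher number from compound 2 to compound 3 (0.04 log units; within the scatter). For compound 3, the estimated value is 12000 nM, with an expected range of 5000 nM to 30000 nM.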

Compound 3, half-maximal inhibitory concentration: 39000 nM
For compound 3 the middle estimate is 3.3-fold (0.51 log units) below the measured one; the measured number lies above the stated range.
By their numbers in this assay, from the lowest: compounds 1 and 2 (each within the scatter of the next); then compound 3.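

In this assay, this aromatic carbon, para to a large group, is not indifferent to substitution: tert-butyl in place of hydrogen gives a step beyond the scatter (a 3.5-fold higher number from compound 2 to compound 3 (0.55 log units; beyond the scatter)), whereas the earlier exchange of 3,4-difluorophenyl for phenyl stayed within it (a 1.9-fold higher number from compound 1 to compound 2 (0.27 log units; within the scatter)). The exchange of 3,4-difluorophenyl for 4-(tert-butyl)phenyl is the largest step in the series (a 6.6-fold higher number from compound 1 to compound 3 (0.82 log units; beyond the scatter)), which makes compound 3 the weakest inhibitor of the three, with its steps to both others beyond the scatter. Nothing at hand gives a reason for this loss.

As far as these compounds go, with tert-butyl as the only substituent at this place, it remains open whether a methyl group would also raise the number. From the compounds shown here alone, an amine or a carboxylic acid at the same carbon is equally open.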